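The source may hold more compounds than are shown below. What is called first, only, known or untested is meant among the compounds shown, and "the series" means these compounds.

Series notes. Within the data shown here, in a functional assay on K562 cells (Homo sapiens) for inhibition, read by trypan blue exclusion, with a stated time of 72 h (on this read-out higher numbers stand for weaker inhibition and lower numbers for stronger inhibition), compound 2 `Cn1c(=O)c(S(=O)(=O)c2ccc(F)cc2F)cc2cnc(Nc3ccc4[nH]ncc4c3)nc21` gives 50000 nM, the highest of the three numbers so far. Compound 3 `Cn1c(=O)c(S(=O)(=O)c2ccc(F)cc2)cc2cnc(Nc3ccc4[nH]ncc4c3)nc21` gives 10000 nM; the change a 5.0-fold lower number from compound 2 to compound 3 (0.70 log units; beyond the scatter) is a modest step. Compound 1 `CCCn1c(=O)c(S(=O)(=O)c2ccc(F)cc2F)cc2cnc(Nc3ccc4[nH]ccc4c3)nc21` gives 1000 nM, the lowest number; it differs from compound 2 in two places, so only the two values themselves can be compared, not a single step.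

Compound 4 `Cn1c(=O)c(S(=O)(=O)c2ccc(F)cc2F)cc2cnc(Nc3cnc4[nH]ccc4c3)nc21` is not yet measured. Relative to compound 2 the change is a group of 9 heavy atoms (7 carbon, 2 nitrogen; one five-membered aromatic ring with 1 hetero atom, one six-membered aromatic ring with 1 hetero atom) in place of a group of 9 heavy atoms (7 carbon, 2 nitrogen; one five-membered aromatic ring with 2 hetero atoms, one six-membered aromatic ring of carbon only), on a nitrogen on an aromatic ring. Among the measured compounds shown here, no measured step covers this exchange of the bicyclic group; the one step in hand concerns a fluoro on the other aryl group. For the measured compounds named here, the exchange therefore rests on no direct precedent, and the expectation is an estimate of a 5.0-fold lower number from compound 2 to compound 4 (0.70 log units; beyond the scatter) for compound 4, toward lower numbers. Compound 4 is thus expected at 10000 nM, within 2500 nM to 40000 nM.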

Compound 4, half-maximal inhibitory concentration: 750 nM
For compound 4 the middle estimate is 13-fold (1.12 log units) above the measured one; the whole stated range lies above it.
By their numbers in this assay, from the lowest: compounds 4 and 1 (each within the scatter of the next); then compound 3; then compound 2.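

In this assay the exchange at this position gives a 67-fold lower number from compound 2 to compound 4 (1.82 log units; beyond the scatter) with the same heavy atoms joined differently and the hydrogen-bond donor and acceptor counts unchanged, so the read-out depends strongly on the bicyclic group itself. That step is larger than a 5.0-fold lower number from compound 2 to compound 3 (0.70 log units; beyond the scatter) on the other aryl group. Nothing at hand accounts for the step. 

Still open, from the compounds shown here alone, is whether the same exchange holds in the setting of compound 3, with hydrogen in place of fluoro. Going by these compounds, how a bicyclic group carrying an amine, or a plain phenyl, would read at this position is also open.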